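Methyl added para on the benzyl of compound 2

A few compounds are considered here, and "the series" means these few. Any claim that something is new, unique, unknown or untested is made for them only; others in the source may bear on it.

Among the measured compounds shown here, compound 2 `O=C(NO)c1ccc(CN2C(=O)NC(Cc3ccccc3)(c3ccccc3)C2=O)cc1` gives 71.9 nM in an assay on isolated protein for inhibition of protein deacetylase HDAC6 (Homo sapiens), read by fluorescence, with stated times of 10 min and 2 h (a higher number here means a weaker inhibitor, a lower number a stronger inhibitor), the higher of the two numbers measured so far. For the measured compounds named here, compound 1 `COc1ccc(CN2CC(=O)N(Cc3ccc(C(=O)NO)cc3)C2=O)cc1` gives 28.2 nM in this assay, a gap beyond the scatter, but the two compounds differ in more than one place and no single step links them. Compound 3 `Cc1ccc(CC2(c3ccccc3)NC(=O)N(Cc3ccc(C(=O)NO)cc3)C2=O)cc1` carries methyl in place of hydrogen on an aromatic carbon. Going by the values given here, no step of this kind has been measured, so no change beyond the scatter is expected in either direction. Compound 3 is expected to give 70 nM, within 30 nM to 170 nM, in this assay. The expected step of a 1.0-fold lower number from compound 2 to compound 3 (0.01 log units; within the scatter) stays within the scatter.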

Compound 3, half-maximal inhibitory concentration: 82.4 nM
Compound 3: the middle estimate sits 1.2-fold (0.07 log units) below what was measured; measured number inside the range.
By their numbers in this assay, from the lowest: compound 1; then compounds 2 and 3 (each within the scatter of the next).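

In this assay, among the compounds shown here, benzyl to 4-methylbenzyl gives the first single-place step, a 1.1-fold higher number from compound 2 to compound 3 (0.06 log units; within the scatter). For the compounds shown here, this aromatic carbon therefore carries a methyl in place of hydrogen with no change beyond the scatter, which the gap between the earlier compounds could not show. No other data bear on this result. Going by these compounds, whether an amine, a carboxylic acid or a longer chain at this carbon would also stay within the scatter remains open. On these data alone, the effect of the same methyl on the other phenyl also remains open.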